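The compounds below may be only part of what the source reports. "The series", "measured", "known", "first", "only" and "open" are said of these compounds alone.

Measured so far in an ADME assay on a cell-free system (plasma, Homo sapiens), read by HPLC, with a stated time of 120 min, at 37 degrees C (a higher number here means that more of the compound is left, a lower number that less of the compound is left), the compounds read as follows

- Compound 1 `C[C@@H]1CN(C(=O)c2nc(Nc3cc(C4CC4)[nH]n3)c3cc(Cl)ccc3n2)CCN1C(=O)OC(C)(C)C` gives 73.7%
- Compound 2 `COC(=O)N1CCN(C(=O)c2nc(Nc3cc(C4CC4)[nH]n3)c3cc(Cl)ccc3n2)C[C@H]1C` gives 84.6%

Compound 2 holds the higher number of the two, and the gap to compound 1 lies beyond the scatter. Not yet measured is compound 3 `CC(C)OC(=O)N1CCN(C(=O)c2nc(Nc3cc(C4CC4)[nH]n3)c3cc(Cl)ccc3n2)C[C@H]1C`, which differs from compound 2 in one place: isopropyl in place of methyl on an oxygen next to a carbonyl group.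

Among the compounds with values here, only one measured step bears on this change, because it concerns the same place: a number 10.9 percentage points higher from compound 1 to compound 2 (beyond the scatter), a modest step with methyl in place of tert-butyl. Read backwards, it suggests that a larger group here may bring a lower number. Isopropyl is larger than methyl but smaller than tert-butyl, so only part of that step is expected to return, and a single step is thin evidence. In this assay the expected result is a number 4.6 percentage points lower from compound 2 to compound 3 (within the scatter), a small drop that would stay within the scatter. For compound 3 the estimated value is 80%, with an expected range from 70% to 89%.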

Compound 3, percent of the compound remaining: 78.5%
Compound 3: middle estimate off by 1.5 percentage points, on the high side; low and high end bracket the measured number.
By their numbers in this assay, from the lowest: compounds 1, 3 and 2 (each within the scatter of the next, the first and the last beyond it).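

In this assay isopropyl on the oxygen next to a carbonyl group gives a result that cannot be separated from either methyl (a number 6.1 percentage points lower from compound 2 to compound 3 (within the scatter)) or tert-butyl (a number 4.8 percentage points higher from compound 1 to compound 3 (within the scatter)). Only methyl and tert-butyl, the smallest and largest of these three groups, lie beyond the scatter of each other (a number 10.9 percentage points higher from compound 1 to compound 2 (beyond the scatter)), so the data show no clear break at any one group, and the isopropyl result alone cannot settle whether the number follows group size in a smooth way. Nothing measured here explains why the group at this position affects how much compound is left.

From the compounds shown here alone, it remains open how an ethyl group or a longer chain would read on this oxygen, which would help show whether the trend across these three compounds holds. Going by these compounds, it is equally open whether an amine in place of this oxygen, turning the group into a urea, would leave more or less of the compound in this assay.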